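Lipophilicity notes: replacing the sulfonamide aryl group

This account rests on a few compounds, and the source may have more. Where it says the series, first, only, none or still open, it means among the compounds named here.

Values so far in a physicochemical assay for lipophilicity (on this read-out lower numbers stand for lower lipophilicity and higher numbers for higher lipophilicity), by compound:
- compound 1 `Cn1nccc1-c1cc(C(F)(F)F)ccc1[C@H]1CCOc2cc(S(=O)(=O)Nc3ccc(F)cn3)ccc21` gives 3.8
- compound 2 `Cc1ccc(-c2cc(C(F)(F)F)ccc2[C@H]2CCc3cc(S(=O)(=O)Nc4ncccn4)ccc32)cn1` gives 2.8
- compound 3 `O=C1COCCN1c1cc(C(F)(F)F)ccc1[C@H]1CCOc2cc(S(=O)(=O)Nc3nccs3)ccc21` gives 1.8

Compound 1 stands highest of the three numbers, and both compound 2 and compound 3 lie below it by more than the scatter. Among the compounds with values here, no two measured compounds differ in only one place, so no measured step bears directly on the next comparison.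

Compound 4 `Cn1nccc1-c1cc(C(F)(F)F)ccc1[C@H]1CCOc2cc(S(=O)(=O)Nc3ccncn3)ccc21` keeps the core of compound 1 and changes one group, with pyrimidin-4-yl in place of 5-fluoropyridin-2-yl on a sulfonamide nitrogen as the only difference.

The nearest guide is compound 2 (2.8), which also has a six-membered aromatic ring with 2 hetero atoms on its sulfonamide nitrogen. Its core differs as well, so its gap to compound 1 cannot be assigned to that group alone. A fall beyond the scatter is nevertheless expected, rather than no change.

The estimated step of a number 1.10 log units lower from compound 1 to compound 4 (beyond the scatter) is a working figure, not a measured one. For compound 4 the expected value is 2.7 with an estimated range of 2.1 to 3.3 in this assay pending measurement.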

Compound 4, distribution coefficient: 1.8
For compound 4 the middle estimate is 0.90 log units above the measured one; the measured number lies below the stated range.
By their numbers in this assay, from the lowest: compounds 3 and 4 (each within the scatter of the next); then compound 2; then compound 1.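

In this assay, pyrimidin-4-yl in place of 5-fluoropyridin-2-yl on a sulfonamide nitrogen, with the shared core kept, gives a large step: a number 2.00 log units lower from compound 1 to compound 4 (beyond the scatter). Within the data shown here, this is the first pair that differs in one place, so the size of a change at this position can now be read apart from any change elsewhere in the molecule. No measurement shown accounts for the size of this step.

The step rests on a single pair and swaps the whole ring, so the loss of fluorine and the change in ring hetero atoms cannot be told apart, and a pyridin-2-yl group without fluorine or a 5-fluoropyrimidin-4-yl group on the same sulfonamide nitrogen would separate the two. The compounds shown also leave open whether the same exchange gives a step of similar size on other cores, and how a non-aromatic group on this nitrogen, such as a cyclopropyl or a short alkyl chain, would compare in this assay with the two aromatic rings.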